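The source may hold more compounds than are shown below. What is called first, only, known or untested is meant among the compounds shown, and "the series" means these compounds.

Compound 2 `COc1cccc(CNCCCNc2ccnc3cc(CCC(C)C)ccc23)c1O` gives 9.47 in a physicochemical assay for acid dissociation. Compound 1 `COc1cccc(CNCCCNc2ccnc3cc(-c4ccc(C(C)(C)C)cc4)ccc23)c1O` gives 9.47 in this assay. no change at the digits printed from compound 1 to compound 2 (within the scatter). The next step leads to compound 3 `COc1ccc(Oc2ccc3c(NCCCNCc4cccc(OC)c4O)ccnc3c2)cc1`, where (4-methoxyphenoxy in place of isopentyl on an aromatic carbon). Among the measured compounds shown here, the only measured step at this position is the one from compound 1 to compound 2, which stayed within the scatter, so no step beyond the scatter is expected in this assay from this further change at the same aromatic carbon. Compound 3 is expected to give 9.47, with a range from 9.2 to 9.8. The expected step is no change at the digits printed from compound 2 to compound 3 (within the scatter).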

Compound 3, acid dissociation constant: 9.28
Compound 3: middle estimate off by 0.19 log units, on the high side; low and high end bracket the measured number.
By their numbers in this assay, from the lowest: compounds 3, 1 and 2 (each within the scatter of the next).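

In this assay, 4-methoxyphenoxy in place of isopentyl reads as a number 0.19 log units lower from compound 2 to compound 3 (within the scatter) and, in place of 4-(tert-butyl)phenyl, as a number 0.19 log units lower from compound 1 to compound 3 (within the scatter); both steps are within the scatter. This aromatic carbon has now carried a group with two hydrogen-bond acceptors, as well as two without any, and no step beyond the scatter has appeared among these compounds. No measured evidence bears on this result. From the compounds shown here alone, whether an amine or a carboxylic acid at this aromatic carbon would give a step beyond the scatter remains open. Also open, going by these compounds, is whether a longer chain there would do so.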